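The compounds below may be only part of what the source reports. "The series", "measured", "known", "first", "only" and "open" are said of these compounds alone.

Measured in a functional assay on A2780 cells (Homo sapiens) for antiproliferative activity; a higher number here means a weaker inhibitor, a lower number a stronger inhibitor:
- compound 1 `CCN1Cc2c(ccc(C)c2C)C(c2ccccc2)C1`: 5300 nM
- compound 2 `Cc1ccc2c(c1C)CN(C(C)C)CC2c1ccccc1`: 6280 nM

Compound 1 stands within the scatter of compound 2, so neither can be ranked. Compound 3 `Cc1ccc2c(c1C)CN(CCCN(C)C)CC2c1ccccc1`, not yet measured, differs from compound 1 by (dimethylamino)methyl in place of hydrogen on a saturated chain carbon, two bonds along the chain from an amine nitrogen in a ring. Put another way, ethyl becomes 3-(dimethylamino)propyl. Going by the values given here, only one measured step bears on this, and only loosely: a 1.2-fold higher number from compound 1 to compound 2 (0.07 log units; within the scatter). Among the compounds with values here, it adds a methyl, and no measured compound carries a dimethylamino group. No step beyond the scatter is therefore expected in this assay, though with wide uncertainty. The expected step is a 1.3-fold lower number from compound 1 to compound 3 (0.12 log units; within the scatter). The estimated value for compound 3 is 4000 nM, with an expected range of 1200 nM to 13000 nM.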

Compound 3, half-maximal inhibitory concentration: 3240 nM
Compound 3: middle estimate off by 1.2-fold (0.09 log units), on the high side; the measured number falls inside the stated range.
By their numbers in this assay, from the lowest: compounds 3, 1 and 2 (each within the scatter of the next).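

On the amine nitrogen in the ring, a chain ending in dimethylamino stays within the scatter in this assay, both for ethyl to 3-(dimethylamino)propyl (a 1.6-fold lower number from compound 1 to compound 3 (0.21 log units; within the scatter)) and for isopropyl to 3-(dimethylamino)propyl (a 1.9-fold lower number from compound 2 to compound 3 (0.29 log units; within the scatter)). This position therefore accepts a longer chain with a second amine without a step beyond the scatter. No supporting data explain this result.

Still open, as far as these compounds go, is whether a longer chain, a piperidine or a carboxylic acid at the chain end would give a step beyond the scatter.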